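The compounds below may be only part of what the source reports. "The series", "measured", "known", "first", "only" and "open" are said of these compounds alone.

Going by the values given here, compound 2 `O=C(COc1ccc2c(=O)cc(-c3ccccc3)oc2c1)NC1CCN(Cc2ccccc2)CC1` holds the only number of the pair in a functional assay on HepG2 cells (Homo sapiens) for cytotoxicity, read by MTT assay, with a stated time of 72 h (a lower number here means a stronger inhibitor, a higher number a weaker inhibitor), where compound 2 gives 16700 nM. Compound 1 `O=C(COc1ccc(-c2cc(=O)c3ccccc3o2)cc1)N1CCN(Cc2ccccc2)CC1` gives > 20000 nM, which is a limit of the assay and not a number; it thus stands at the limit of > 20000 nM in this assay, at which 1 of the 2 values shown sits. Compound 3 `N#Cc1ccc(CN2CCC(NC(=O)COc3ccc4c(=O)cc(-c5ccccc5)oc4c3)CC2)cc1` differs from compound 2 by cyano in place of hydrogen on an aromatic carbon. No measured step links any two of these compounds, so nothing here gauges such a change. The expected step from compound 2 to compound 3 in this assay is a 1.1-fold lower number from compound 2 to compound 3 (0.05 log units; within the scatter), none beyond the scatter. Compound 3 is therefore estimated at 15000 nM in this assay, within 6000 nM to 40000 nM.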

Compound 3, half-maximal inhibitory concentration: 9300 nM
Compound 3: middle estimate off by 1.6-fold (0.21 log units), on the high side; the measured number falls inside the stated range.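

Going from benzyl to 4-cyanobenzyl gives the first measured step at this position in this assay: a 1.8-fold lower number from compound 2 to compound 3 (0.25 log units; within the scatter). Cyano on this aromatic carbon, para to a large group, therefore does not carry the number beyond the scatter. Nothing in the data at hand accounts for this step.

Going by these compounds, whether an amine, a carboxylic acid or a methoxy group at this same place would go beyond the scatter stays open. So does the outcome of cyano on another carbon of that ring.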